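This account rests on a few compounds, and the source may have more. Where it says the series, first, only, none or still open, it means among the compounds named here.

Measured so far:
- compound 1, `Cn1ncc(Cl)c1-c1cc(C(=O)N[C@@H]2CN[C@H](CCN3CCC(O)CC3)C[C@H]2c2ccc(Cl)c(Cl)c2)oc1Cl`, 5.99 nM
- compound 2, `Cn1ncc(Cl)c1-c1cc(C(=O)N[C@@H]2CNCC[C@H]2c2ccc(C(F)(F)F)cc2)oc1Cl`, 9.3 nM
- compound 3, `Cn1ncc(Cl)c1-c1cc(C(=O)N[C@@H]2CN[C@H](CCO)C[C@H]2c2ccc(F)c(F)c2)oc1Cl`, 0.98 nM

All three were run in an assay for inhibition of RAC-alpha serine/threonine-protein kinase (Homo sapiens), read by HTRF, with a stated time of 1 h; a higher number here means a weaker inhibitor, a lower number a stronger inhibitor. Compound 1 stands second highest of the three numbers; compound 2 lies within the scatter of it, so no order between those two is claimed, whereas compound 3 sits beyond the scatter on the lower side. For the measured compounds named here, compound 2 and compound 3 differ from compound 1 in more than one place, so no single step is drawn from them.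

Compound 4, `Cn1ncc(Cl)c1-c1cc(C(=O)N[C@@H]2CN[C@H](CC(=O)NCC(O)CO)C[C@H]2c2ccc(Cl)c(Cl)c2)oc1Cl`, keeps the core and the dichlorophenyl group of compound 1 and changes only the side chain: (2,3-dihydroxypropyl)carbamoyl in place of (4-hydroxypiperidin-1-yl)methyl on a saturated chain carbon bound to a saturated ring carbon. Going by the values given here, the measured set offers no direct step for this kind of swap, only the observation that compound 2, bare at this position, and compound 3, carrying a hydroxyethyl chain, both give numbers that bracket compound 1 in this assay. A step from compound 1 to compound 4 of about a 1.2-fold lower number from compound 1 to compound 4 (0.08 log units; within the scatter) is therefore expected, that is, none beyond the scatter in either direction. Compound 4 is estimated at 5 nM, with a range of 1.5 nM to 15 nM.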

Compound 4, half-maximal inhibitory concentration: 3.13 nM
For compound 4 the middle estimate is 1.6-fold (0.20 log units) above the measured one; the range from low to high includes it.
By their numbers in this assay, from the lowest: compound 3; then compounds 4, 1 and 2 (each within the scatter of the next, the first and the last beyond it).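

In this assay, the side chain now has its first direct step: a 1.9-fold lower number from compound 1 to compound 4 (0.28 log units; within the scatter). At this position on a saturated chain carbon bound to a saturated ring carbon, the six-membered non-aromatic ring of (4-hydroxypiperidin-1-yl)methyl can therefore give way to the open (2,3-dihydroxypropyl)carbamoyl chain, going from 1 hydrogen-bond donor to 3, with the number staying within the scatter. No measurement at hand gives a reason for this outcome.

Open, from the compounds shown here alone, is whether a carboxylic acid, a primary amine or a longer chain in this place would also stay within the scatter of compound 1. Compound 3 differs from compound 4 in more than one place, so the side chain's contribution cannot be separated from that of the halogens on the phenyl ring.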